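The source may hold more compounds than are shown below. What is called first, only, known or untested is meant among the compounds shown, and "the series" means these compounds.

Measured so far:
Compound 1, `COc1ccc2c(c1O)CCCC(CCC#N)=C2c1cc(OC)c(OC)c(OC)c1`, in an ADME assay (liver) for metabolic stability, with Liver microsome (Homo sapiens) as the target, using microsomes, tested at 1 uM (a higher number here means faster removal of the compound, a lower number slower removal), gives > 320 mL.min-1.g-1, which is a limit of the assay and not a number.
Compound 2, `COc1ccc2c(c1O)CCCC(CCCC#N)=C2c1cc(OC)c(OC)c(OC)c1`, in this assay gives 239 mL.min-1.g-1.

Compound 1 stands at the limit, as the limit of > 320 mL.min-1.g-1 in this assay, at which 1 of the 2 values shown sits, records. Compound 3, `COc1ccc2c(c1O)CCCC(Cc1ccccc1)=C2c1cc(OC)c(OC)c(OC)c1`, differs from compound 1 by phenyl in place of cyanomethyl on a saturated chain carbon bound to a double-bonded ring carbon. Going by the values given here, the only measured step, an at least 1.3-fold lower number from compound 1 to compound 2 (0.12 log units; that floor lies within the scatter), concerns a different change and lies within the scatter. Among the compounds with values here, with compound 1 at a limit, no step from it can be sized from what is known, and the expectation for compound 3 rests on compound 1 alone. Compound 3 is expected to give 400 mL.min-1.g-1, between 200 mL.min-1.g-1 and 800 mL.min-1.g-1. The estimated step is a step that the limit leaves unreadable from compound 1 to compound 3.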

Compound 3, intrinsic clearance in microsomes: 51.2 mL.min-1.g-1
Estimate against measurement, compound 3: 7.8-fold (0.89 log units) above, and the stated range ends above it.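

In this assay, this position can carry a change beyond the scatter, which the earlier pair did not show: phenyl in place of 2-cyanoethyl gives a 4.7-fold lower number from compound 2 to compound 3 (0.67 log units; beyond the scatter). Phenyl in place of cyanomethyl gives an at least 6.2-fold lower number from compound 1 to compound 3 (0.79 log units; beyond the scatter). Compound 1 stands at a limit, not a number, so that step is only a floor: the limit of > 320 mL.min-1.g-1 in this assay, at which 1 of the 3 values shown sits.

The compounds shown do not separate the loss of the nitrile from the arrival of the aromatic ring. On these data alone, how a cyclohexyl group or a chain ending in an amine would fare here remains open.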